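A few compounds are considered here, and "the series" means these few. Any claim that something is new, unique, unknown or untested is made for them only; others in the source may bear on it.

Measured compounds:
- compound 1 `COc1ccc(C(=O)/C=C/c2cc3ccccc3[nH]c2=O)cc1`: > 100000 nM in an ADME assay on U-251 cells (Homo sapiens) for cytotoxicity, read by sulforhodamine B assay, with a stated time of 24 h; on this read-out higher numbers stand for lower toxicity in this test and lower numbers for higher toxicity in this test 
- compound 2 `O=C(/C=C/c1cc2ccccc2[nH]c1=O)c1ccc(O)cc1`: 45300 nM 

In this assay compound 1 reaches only a limit, (the limit of > 100000 nM in this assay, at which 1 of the 2 values shown sits), and not a number. Going by the values given here, compound 2 therefore gives the only number among the two values shown, the other value being a limit. The unmeasured compound 3 `O=C(/C=C/c1cc2ccccc2[nH]c1=O)c1ccc(Cl)cc1` differs from compound 2 in one place: chloro in place of hydroxy on an aromatic carbon. Among the compounds with values here, the single measured step, an at least 2.2-fold lower number from compound 1 to compound 2 (0.34 log units; beyond the scatter), is the one that bears on it, since it also touched the hydroxy group that now leaves; it ran toward higher toxicity and was at least modest. Because the value of compound 1 > 100000 nM is a limit, the size of that step is only partly known. The step of a 1.3-fold higher number from compound 2 to compound 3 (0.12 log units; within the scatter) is expected to be small, with a wide range of uncertainty. Compound 3 is estimated at 60000 nM, between 20000 nM and 150000 nM.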

Compound 3, concentration lethal to 50% of the cells: 39700 nM
Compound 3: the middle estimate sits 1.5-fold (0.18 log units) above what was measured; the measured number falls inside the stated range.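

In this assay, chloro in place of hydroxy gives a 1.1-fold lower number from compound 2 to compound 3 (0.06 log units; within the scatter), so these two groups cannot be told apart at this position, even though hydroxy carries a hydrogen-bond donor and acceptor and chloro carries neither. Chloro in place of methoxy gives an at least 2.5-fold lower number from compound 1 to compound 3 (0.40 log units; beyond the scatter), so two different groups now read as more toxic than methoxy, and of the three groups only methoxy fails to give a number. The size of that step is only partly known, since the value of compound 1 is a limit: the limit of > 100000 nM in this assay, at which 1 of the 3 values shown sits.

The compounds shown leave open whether an amine or a carboxylic acid at this position would read like compound 2 and compound 3, or like compound 1. They also leave open whether a longer ether chain, such as ethoxy, would behave as methoxy does.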